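Semicarbazone to thiosemicarbazone: cytotoxicity on hamster kidney cells

This account rests on a few compounds, and the source may have more. Where it says the series, first, only, none or still open, it means among the compounds named here.

Measured compounds:
compound 1, `C/C(=N\NC(N)=O)c1ccc2[nH]c(-c3ccc(C(F)(F)F)cc3)nc2c1`: > 100000 nM
compound 2, `C/C(=N\NC(N)=S)c1ccc2[nH]c(-c3ccc(C(F)(F)F)cc3)nc2c1`: 5000 nM
compound 3, `C/C(=N\NC(N)=O)c1ccc2c(c1)nc(-c1ccccc1)n2C1CCCCC1`: > 100000 nM

In an ADME assay on BHK-21 cells (Mesocricetus auratus) for cytotoxicity, read by MTT assay (a lower number here means that less compound is tolerated, a higher number that more compound is tolerated), compound 1 reaches only the limit of the assay, > 100000 nM; no number is reported. In this assay compound 2 gives 5000 nM. The change between them is a group of 3 heavy atoms (1 carbon, 1 nitrogen, 1 sulfur; no ring) in place of a group of 3 heavy atoms (1 carbon, 1 nitrogen, 1 oxygen; no ring), on an amine nitrogen. It made an at least 20-fold lower number from compound 1 to compound 2 (1.30 log units; beyond the scatter). This step is the sole measured comparison of this kind in the set.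

In this assay compound 3 also sits at the limit of the assay, > 100000 nM, without a number. How the core of compound 3 differs from the core of compound 1 is not broken down here.

Compound 4, `C/C(=N\NC(N)=S)c1ccc2c(c1)nc(-c1ccccc1)n2C1CCCCC1`, is not yet measured. It differs from compound 3 by a group of 3 heavy atoms (1 carbon, 1 nitrogen, 1 sulfur; no ring) in place of a group of 3 heavy atoms (1 carbon, 1 nitrogen, 1 oxygen; no ring), on an amine nitrogen, the same change as between compound 1 and compound 2. Since compound 3 stands at the limit of > 100000 nM in this assay, at which 2 of the 3 values shown sit, the expected step of an at least 12-fold lower number from compound 3 to compound 4 (1.09 log units; beyond the scatter) is taken from the measured one, and a number below the limit is expected. In this assay compound 4 is estimated at 8000 nM, within 2000 nM to 50000 nM.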

Compound 4, half-maximal cytotoxic concentration: 38000 nM
Compound 4: middle estimate off by 4.8-fold (0.68 log units), on the low side; the range from low to high includes it.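

Carried to the second core, the change from carbamoyl to its sulfur-containing counterpart on the amine nitrogen again lowers the number in this assay, giving an at least 2.6-fold lower number from compound 3 to compound 4 (0.42 log units; beyond the scatter), so the direction is the same on both cores shown. Compound 3 gives > 100000 nM, which is a limit of the assay and not a number. The direction therefore carries over, but whether the size of the step also carries over is not shown: the same change on two cores in this assay, an at least 20-fold lower number (1.30 log units; beyond the scatter) from compound 1 to compound 2 and an at least 2.6-fold lower number (0.42 log units; beyond the scatter) from compound 3 to compound 4; the limit leaves it open whether they differ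

Sizing the change on any core would take a semicarbazone that gives a number rather than a limit, together with its sulfur-containing counterpart. Also open is how the change reads on cores carrying other groups, such as an amine, a carboxylic acid or a longer chain in place of the trifluoromethyl or the cyclohexyl, since only two cores are shown and these differ from each other in more than one place.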